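A few compounds are considered here, and "the series" means these few. Any claim that something is new, unique, unknown or untested is made for them only; others in the source may bear on it.

Working notes on the series in a functional assay on SGC-7901 cells (Homo sapiens) for antiproliferative activity, read by MTT assay, with a stated time of 72 h; on this read-out lower numbers stand for stronger inhibition and higher numbers for weaker inhibition. Compound 1 (`CCOc1ccc(-c2ccc3ncn(-c4cc(OC)c(OC)c(OC)c4)c3c2)cc1`) gives 2970 nM and compound 2 (`COc1cc(-n2cnc3ccc(-c4cccc(Cl)c4)cc32)cc(OC)c1OC`) gives 1490 nM. For the measured compounds named here, these two values lie within the scatter of each other, so compound 2 stands level with compound 1 on the only two numbers available.

Compound 3 (`COc1cc(-n2cnc3ccc(-c4cccc(F)c4)cc32)cc(OC)c1OC`) has fluoro in place of chloro on an aromatic carbon, meta to a large group: fluoro in place of chloro on an aromatic carbon.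

Going by the values given here, the one measured step bearing on this change is a 2.0-fold lower number from compound 1 to compound 2 (0.30 log units; within the scatter). It exchanges 4-ethoxyphenyl for 3-chlorophenyl and stays within the scatter. Among the compounds with values here, no measured step exchanges chloro for fluoro directly, so the evidence is thin. No step beyond the scatter is expected in this assay, and no direction is favoured.

The expected step is a 1.1-fold higher number from compound 2 to compound 3 (0.06 log units; within the scatter). Compound 3 is estimated at 1700 nM, with an expected range of 650 nM to 4500 nM.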

Compound 3, half-maximal inhibitory concentration: 2490 nM
Compound 3: the middle estimate sits 1.5-fold (0.17 log units) below what was measured, within the range that was stated.
By their numbers in this assay, from the lowest: compounds 2, 3 and 1 (each within the scatter of the next).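

In this assay the direct exchange gives a 1.7-fold higher number from compound 2 to compound 3 (0.22 log units; within the scatter) for fluoro in place of chloro, meta to a large group, so the two halogens stand level at this position. The wider exchange of 4-ethoxyphenyl for 3-fluorophenyl gives a 1.2-fold lower number from compound 1 to compound 3 (0.08 log units; within the scatter) and likewise stays inside the scatter, so the three aryl groups shown cannot be told apart on this read-out. Nothing measured here accounts for this level standing.

From the compounds shown here alone, whether an amine or a carboxylic acid on the same aromatic carbon would give a step beyond the scatter remains open. The compounds shown also leave open whether any change elsewhere on the shared core would separate compounds in this assay.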